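This account rests on a few compounds, and the source may have more. Where it says the series, first, only, none or still open, it means among the compounds named here.

Measured so far:

Compound 1, `NC(=O)c1nc2ccccn2c1[N+](=O)[O-]`: -0.54
Compound 2, `Cc1cccc2nc(C(N)=O)c([N+](=O)[O-])n12`: 0.695
Compound 3, `Cc1cccc2nc(NC3CCCCC3)c([N+](=O)[O-])n12`: 1.5

All three compounds were tested in a physicochemical assay for lipophilicity, measured as octanol-water partition; on this read-out lower numbers stand for lower lipophilicity and higher numbers for higher lipophilicity. Compound 3 stands highest of the three in this assay, with compound 2 nearer to it and compound 1 furthest away, and both gaps lie beyond the usual scatter of the method. Compound 1 and compound 2 share a core and differ in one place: hydrogen in place of methyl on an aromatic carbon. That single change produced a number 1.24 log units lower from compound 2 to compound 1 (beyond the scatter), a step well beyond the scatter. How the core of compound 3 differs from the core of compound 2 is not broken down here.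

Compound 4, `O=[N+]([O-])c1c(NC2CCCCC2)nc2ccccn12`, has not yet been measured. It is related to compound 3 by exactly the same change that links compound 2 to compound 1: hydrogen in place of methyl on an aromatic carbon. The words describing the place of the change are the same in both pairs, so the two changes are the same change, made on two different cores.

For this assay the expectation is that compound 4 will come out lower than compound 3, with an expected step of a number 1.00 log units lower from compound 3 to compound 4 (beyond the scatter). Among the compounds with values here, this rests on the one earlier instance of the change, which gave a number 1.24 log units lower from compound 2 to compound 1 (beyond the scatter), although a single instance on a different core leaves the size uncertain. The estimated value for compound 4 in this assay is 0.5, with a likely range from -0.1 to 1.1.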

Compound 4, partition coefficient: 1.5
Beside the measured number, compound 4's estimate is 1.00 log units below it, and the stated range ends below it.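

In this assay, putting hydrogen in place of methyl on an aromatic carbon gave no change at the digits printed from compound 3 to compound 4 (within the scatter), whereas the same change on the other core gave a number 1.24 log units lower from compound 2 to compound 1 (beyond the scatter). This shows that the step seen on one core cannot simply be carried over to another core in this series, since the same swap gave a step beyond the scatter in one pair and none beyond it in the other, and compound 3 and compound 4 cannot be told apart on this read-out. It does not show how the change would behave on any further core, as two pairs cannot establish a rule, and no measurement shown here bears on why the two pairs gave different results.

The compounds shown leave open how an ethyl group or a methoxy group would read in the place of the methyl on either core, which would show whether the contrast is limited to the swap between methyl and hydrogen. They also leave open whether a third core, such as one carrying a carboxylic acid, would follow the pair of compound 1 and compound 2 or the pair of compound 3 and compound 4.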